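Working notes on the aryl swap at the ring nitrogen

The source may report more compounds than this note shows. Statements on the series, on what has been measured and on what is new or still open speak of the compounds shown alone.

Compound 2 `CC1(C)[C@@H]2CC[C@@]1(CS(=O)(=O)N1CCN(c3ccc([N+](=O)[O-])cn3)CC1)C(=O)C2` stands at the ceiling of a functional assay on CHO-K1 cells for antagonist activity at C-X-C chemokine receptor type 3 (Homo sapiens), read by FLIPR and calcium flux; a higher number here means a weaker inhibitor, a lower number a stronger inhibitor: compound 2 gives > 31600 nM, which is a limit and not a number. Compound 1 `Cc1ccc(N2CCN(S(=O)(=O)C[C@]34CC[C@H](CC3=O)C4(C)C)CC2)nc1` likewise gives > 31600 nM in this assay, also a limit. The step that the two limits leave unreadable from compound 1 to compound 2 is therefore unreadable, and the limit of > 31600 nM in this assay, at which 2 of the 2 values shown sit, is all the series shows. Compound 3 `CC1(C)[C@@H]2CC[C@@]1(CS(=O)(=O)N1CCN(c3ccc(C(F)(F)F)cc3)CC1)C(=O)C2` carries 4-(trifluoromethyl)phenyl in place of 5-nitropyridin-2-yl on an amine nitrogen in a ring. For the measured compounds named here, no measured step bears on this change, so no size or direction can be expected beyond the scatter. The step of a number no higher from compound 2 to compound 3 (the limit leaves the size open) is expected to stay near the limit. Compound 3 is estimated at 31600 nM, within 10000 nM to 100000 nM.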

Compound 3, half-maximal inhibitory concentration: > 31600 nM
Compound 3 was reported as a limit; the forecaster's own chance of this, stated with the estimate: 75%; the middle value sits exactly at the limit.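

No new step can be read among compound 1, compound 2 and compound 3, because all three values are the same limit: the limit of > 31600 nM in this assay, at which 3 of the 3 values shown sit.

The compounds shown leave open whether any aryl group on the ring nitrogen of the shared core gives a value short of that limit.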